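Removing a Methyl from the Core of Compound 1

This account rests on a few compounds, and the source may have more. Where it says the series, first, only, none or still open, it means among the compounds named here.

Going by the values given here, compound 1 `Cn1c(Cc2nn(C)c(=O)c3ccccc23)nnc1SCCCCCCCC(=O)Nc1ccc(Cl)cc1Cl` is one of three compounds measured in an assay on 32D cells for inhibition of interleukin-15 (Mus musculus), read by resazurin assay, with stated times of 30 min and 2.5 days, in the presence of a further agent that is not named here (a lower number here means a stronger inhibitor, a higher number a weaker inhibitor), where compound 1 gives 2200 nM. Among these three numbers it stands second highest. Compound 2 `Cn1nc(Cc2nnc(SCCCCCCCC(=O)Nc3ccc(Cl)cc3Cl)[nH]2)c2ccccc2c1=O` gives 1100 nM, and compound 3 `CN(C)CCCn1c(Cc2nn(C)c(=O)c3ccccc23)nnc1SCCCCCCCC(=O)Nc1ccc(Cl)cc1Cl` gives 3700 nM. Compound 4 `Cn1c(Cc2n[nH]c(=O)c3ccccc23)nnc1SCCCCCCCC(=O)Nc1ccc(Cl)cc1Cl` has not been measured; it differs from compound 1 by hydrogen in place of methyl on an aromatic nitrogen. Among the compounds with values here, the step that bears most on this is the one from compound 1 to compound 2, the same kind of change made at a different place in the shared core: a 2.0-fold lower number from compound 1 to compound 2 (0.30 log units; within the scatter). The step of a 1.7-fold higher number from compound 1 to compound 3 (0.23 log units; within the scatter) adds a chain elsewhere and also stays within the scatter. The change to compound 4 is therefore expected to bring no step beyond the scatter in this assay, a 1.3-fold lower number from compound 1 to compound 4 (0.11 log units; within the scatter). Compound 4 is estimated at 1700 nM, within a range of 700 nM to 4500 nM.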

Compound 4, half-maximal inhibitory concentration: > 30000 nM
Compound 4: no number, only a limit (the forecaster's own chance of this, stated with the estimate: 5%); middle value at least 17-fold (1.24 log units) away from the limit.
By their numbers in this assay, from the lowest: compounds 2, 1 and 3 (each within the scatter of the next, the first and the last beyond it). At a limit, above all of these: compound 4.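

In this assay, hydrogen in place of methyl on this aromatic nitrogen is a large change, an at least 13-fold higher number from compound 1 to compound 4 (1.13 log units; beyond the scatter), whereas the same kind of change elsewhere in the shared core stays within the scatter, a 2.0-fold lower number from compound 1 to compound 2 (0.30 log units; within the scatter). The two methyl positions therefore cannot be treated as equivalent, and only this one is shown to matter. For compound 4 the result is a limit and not a number: the limit of > 30000 nM in this assay, at which 1 of the 4 values shown sits.

On these data alone, whether an ethyl group, a longer chain or an amine on this nitrogen would keep a number close to that of compound 1 stays open. The compounds shown also do not tell how far past its limit compound 4 lies.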